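The compounds below may be only part of what the source reports. "The series", "measured", "known", "first", "only" and "open" are said of these compounds alone.

Series notes. Going by the values given here, the common core of this set is the one seen in compound 1, `COc1cccc(/C=C/C(=O)c2cc3cc(O)ccc3oc2=O)c1OC`, which in a functional assay on MOLT-4 cells (Homo sapiens) for cytotoxicity, read by MTT assay, with a stated time of 72 h (on this read-out lower numbers stand for stronger inhibition and higher numbers for weaker inhibition), gives 6700 nM. Compound 3, `COc1cc(/C=C/C(=O)c2cc3cc(OCc4ccccc4)ccc3oc2=O)cc(OC)c1OC`, carries a benzyloxy group in place of the free hydroxyl on that core together with a trimethoxyphenyl on the chain, and in this assay compound 3 gives 10300 nM. The two measured numbers lie close to one another; neither can be called stronger than the other on these data.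

Compound 2, `COc1cccc(COc2ccc3cc(C(=O)/C=C/c4ccc(Cl)cc4Cl)c(=O)oc3c2)c1`, has in this assay only the entry "not determined" (no result reported): nothing was reported, so it stands nowhere on the numbers shown and gives no anchor of its own.

Compound 4, `COc1cccc(COc2ccc3cc(C(=O)/C=C/c4ccc(C)cc4)c(=O)oc3c2)c1`, differs from compound 2 in one place: 4-methylphenyl in place of 2,4-dichlorophenyl on a double-bonded chain carbon bound to a double-bonded chain carbon. With compound 2 unmeasured, the step from compound 2 to compound 4 cannot be sized from data. Going by the two measured analogues, which differ from each other at the aryl end and at the ring substituent yet come out alike, the expectation is that swapping the aryl group here produces no step in this assay beyond the scatter, in either direction.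

Compound 4 is therefore expected to come out near the measured pair, estimated at 8000 nM with a range from 2500 nM to 25000 nM.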

Compound 4, half-maximal inhibitory concentration: > 50000 nM
Compound 4: a limit, no number (the forecaster's own chance of this, stated with the estimate: 15%); middle value at least 6.2-fold (0.79 log units) from the limit.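

In this assay compound 4 gives > 50000 nM, which is a limit and not a number. Compound 2 has no number to set against it, so no step can be read between compound 2 and compound 4. The compounds shown leave open how 2,4-dichlorophenyl and 4-methylphenyl compare at this place on the chain.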